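The compounds below may be only part of what the source reports. "The series", "measured", "known", "first", "only" and "open" are said of these compounds alone.

Of the compounds shown here, two have been tested so far in a functional assay on DLD-1 cells (Homo sapiens) for antiproliferative activity, read by CellTiter-Glo, with a stated time of 72 h; on this read-out higher numbers stand for weaker inhibition and lower numbers for stronger inhibition. Compound 1, `Cc1cc(C)c(S(=O)(=O)NCCN2CCC(C)CC2)c(C)c1`, gives 1900 nM in this assay. Compound 2, `C#CCOCCC1CCCCN1C1CCN(S(=O)(=O)c2ccccc2)CC1`, carries a piperidine-linked side chain and a different sulfonamide; in this assay compound 2 reaches only a limit of the measurement, > 5000 nM, so no number is known for it, just the boundary (the limit of > 5000 nM in this assay, at which 1 of the 2 values shown sits), and compound 2 is therefore weaker than compound 1 on the numbers shown without its distance being measurable.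

Compound 3, `C#CCC1CCCCN1C1CCN(S(=O)(=O)c2ccccc2)CC1`, is the untested partner of compound 2. The change is ethynyl in place of (propargyloxy)methyl on a saturated chain carbon bound to a saturated ring carbon; read one bond further out, the same difference turns 2-(propargyloxy)ethyl into propargyl, so the triple bond is kept but the chain between it and the ring is cut short.

For the measured compounds named here, with no measured pair of this kind to lean on, the step that the limit leaves unreadable from compound 2 to compound 3 is expected to be small, with the limit itself the most likely outcome again. Compound 3 is accordingly estimated at 6000 nM, within a range from 2000 nM to 20000 nM.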

Compound 3, half-maximal inhibitory concentration: > 5000 nM
Compound 3 was reported as a limit (the forecaster's own chance of this, stated with the estimate: 60%); the middle value does not contradict the limit.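

Compound 2 and compound 3 both end at a limit of the measurement rather than at a number, so no step between them can be read: the limit of > 5000 nM in this assay, at which 2 of the 3 values shown sit.

From the compounds shown here alone, what stays open is whether ethynyl in place of (propargyloxy)methyl changes the result in this assay at all, and how much activity either compound actually has.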